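The source may report more compounds than this note shows. Statements on the series, on what has been measured and on what is new or still open speak of the compounds shown alone.

The measured compounds:
Compound 1 `N#CNC(=N)NCCCCCn1nc(-c2ccccc2)ccc1=O` — in a functional assay on the whole organism (stomach) with Rattus norvegicus as the target (a lower number here means that less compound is needed, a higher number that more compound is needed for the effect), compound 1 gives > 100 mg/kg, which is a limit of the assay and not a number.
Compound 2 `O=c1ccc(-c2ccccc2)nn1CCCCNC(=S)Nc1ccccc1` — in this assay compound 2 gives > 100 mg/kg, again only a limit.
Compound 3 `O=c1ccc(-c2ccccc2)nn1CCCCNC(=S)Nc1cccc2ccccc12` — in this assay compound 3 gives > 100 mg/kg, also a limit.

Compound 2 therefore stands at a limit and nowhere else: no true number is known for it, and the two further values shown are limits as well, all three sitting at the limit of > 100 mg/kg in this assay, at which 3 of the 3 values shown sit. For the measured compounds named here, the one measured step that changes a single place, a step that the two limits leave unreadable from compound 2 to compound 3, cannot be read at all, since both of its ends are limits.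

Compound 4 `C/N=C(\NC#N)NCCCCn1nc(-c2ccccc2)ccc1=O` arises from compound 2 by the change (a group of 6 heavy atoms (3 carbon, 3 nitrogen; no ring) in place of a group of 9 heavy atoms (7 carbon, 1 nitrogen, 1 sulfur; one six-membered aromatic ring of carbon only), on an amine nitrogen). Going by the values given here, no measured step mirrors this exchange, so it gives no size to lean on. Among the compounds with values here, the only hint comes from compound 1, which carries a related ring-free end group and also sits at the limit of > 100 mg/kg in this assay, at which 3 of the 3 values shown sit.

On that basis the step that the limit leaves unreadable from compound 2 to compound 4 is expected to show nothing readable beyond the scatter, and compound 4 is expected to give 150 mg/kg, within 50 mg/kg to 500 mg/kg, most probably reported once more only as a limit.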

Compound 4, dose for half-maximal effect: 32.4 mg/kg
Beside the measured number, compound 4's estimate is 4.6-fold (0.67 log units) above it; measured number below the stated range.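

In this assay, for the compounds shown here, putting the ring-free group of 6 heavy atoms on the amine nitrogen in place of the group of 9 heavy atoms, with its six-membered aromatic ring, gives an at least 3.0-fold lower number from compound 2 to compound 4 (0.48 log units; beyond the scatter); this is the first sign that the end of the chain can change the dose needed, which the earlier compounds could not show. Lacking a ring is not enough by itself, since exchanging one ring-free group for another, on the saturated chain carbon, gives an at least 3.0-fold lower number from compound 1 to compound 4 (0.48 log units; beyond the scatter). Both steps give only a minimum size, because each starts from a compound with no true number, and compound 4 is the only one here to leave that limit: the limit of > 100 mg/kg in this assay, at which 3 of the 4 values shown sit.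

Going by these compounds, the step between compound 2 and compound 3 cannot be read, since both of its ends are limits, so the effect of the larger aromatic group on the amide-type nitrogen remains unknown. On these data alone, it also remains open whether an amine or a carboxylic acid at this end, or a longer chain, would lower the dose further or lose the effect.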